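A few compounds are considered here, and "the series" means these few. Any claim that something is new, unique, unknown or untested is made for them only; others in the source may bear on it.

Measured compounds, in a functional assay on HepG2 cells (Homo sapiens) for inhibition, with a stated time of 72 h; on this read-out higher numbers stand for weaker inhibition and lower numbers for stronger inhibition:

Compound 1 `COc1ccc(NC(=O)Nc2nc(Sc3c[nH]c4ccccc34)cc(N3CCN(c4ccccn4)CC3)n2)cc1` gives 11400 nM.
Compound 2 `O=C(Nc1ccccc1)Nc1nc(Sc2c[nH]c3ccccc23)cc(N2CCN(Cc3ccccc3)CC2)n1` gives 8160 nM.
Compound 3 `Cc1ccc(C)c(NC(=O)Nc2nc(Sc3c[nH]c4ccccc34)cc(N3CCN(Cc4ccccc4)CC3)n2)c1` gives 16400 nM.

Compound 3 has the highest of these three numbers, but its gaps to compound 1 and to compound 2 are both within the scatter, so the three compounds cannot be told apart on this read-out. Compound 4 `COc1ccc(NC(=O)Nc2nc(Sc3c[nH]c4ccccc34)cc(N3CCN(Cc4ccccc4)CC3)n2)cc1` differs from compound 3 in one place: 4-methoxyphenyl in place of 2,5-dimethylphenyl on an amide-type nitrogen. Among the compounds with values here, one measured step touches the same position: a 2.0-fold higher number from compound 2 to compound 3 (0.30 log units; within the scatter), an exchange of one aromatic ring for another that moved the number only within the scatter. Within the data shown here, no measured pair compares 2,5-dimethylphenyl directly with 4-methoxyphenyl while everything else is held fixed; compound 1 carries the 4-methoxyphenyl but also a different group elsewhere on the shared core, and compound 1 gives 11400 nM, close to the other two. On this basis the expected step from compound 3 to compound 4 is a 1.5-fold lower number from compound 3 to compound 4 (0.17 log units; within the scatter), with no change beyond the scatter. Compound 4 is therefore estimated at 11000 nM, in a range from 5000 nM to 25000 nM.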

Compound 4, half-maximal inhibitory concentration: 21400 nM
Estimate against measurement, compound 4: 1.9-fold (0.29 log units) below, within the range that was stated.
By their numbers in this assay, from the lowest: compounds 2, 1, 3 and 4 (each within the scatter of the next, the first and the last beyond it).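

In this assay, the direct exchange of 2,5-dimethylphenyl for 4-methoxyphenyl on the amide-type nitrogen gives a 1.3-fold higher number from compound 3 to compound 4 (0.12 log units; within the scatter) and so does not separate these two groups. Methoxy in place of hydrogen on the aromatic carbon of the plain phenyl gives a 2.6-fold higher number from compound 2 to compound 4 (0.42 log units; beyond the scatter) and is the first modest weakening of inhibition at this position, yet it cannot be ranked above the 2,5-dimethylphenyl change, which gives a 2.0-fold higher number from compound 2 to compound 3 (0.30 log units; within the scatter) and stays close to it. Elsewhere on the shared core, benzyl in place of pyridin-2-yl on the amine nitrogen in a ring gives a 1.9-fold higher number from compound 1 to compound 4 (0.27 log units; within the scatter) and shows no clear effect of that exchange.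

The compounds shown leave open whether an amine or a carboxylic acid on this aromatic ring would strengthen inhibition rather than leave it in this narrow band. No available evidence explains the modest step from the added methoxy.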